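The compounds below may be only part of what the source reports. "The series", "measured", "known", "first", "only" and "open" are said of these compounds alone.

In a functional assay on HL-60 cells (Homo sapiens) for inhibition, read by CCK-8 assay, with a stated time of 48 h (on this read-out lower numbers stand for stronger inhibition and higher numbers for weaker inhibition), two compounds sharing one core have been measured. Compound 1 `O=C(NCCNS(=O)(=O)c1ccc(-c2ccccc2OCc2cccc(O)c2)s1)Nc1cc(C(F)(F)F)cc(C(F)(F)F)c1` gives 4000 nM and compound 2 `O=C(NCCNS(=O)(=O)c1ccc(-c2ccccc2O[C@H]2CC[C@@H](O)CC2)s1)Nc1cc(C(F)(F)F)cc(C(F)(F)F)c1` gives 3100 nM. Compound 2 therefore stands level with compound 1, as the step between them, a 1.3-fold lower number from compound 1 to compound 2 (0.11 log units; within the scatter), does not separate the two. Compound 3 `Nc1ccc(Oc2ccccc2-c2ccc(S(=O)(=O)NCCNC(=O)Nc3cc(C(F)(F)F)cc(C(F)(F)F)c3)s2)cc1` keeps the same core and alters the group at that same place: 4-aminophenyl in place of 4-hydroxycyclohexyl on an oxygen on an aromatic ring. In short, it carries 4-aminophenyl in place of 4-hydroxycyclohexyl on an oxygen on an aromatic ring. Within the data shown here, only one measured step bears on this change, the exchange of 3-hydroxybenzyl for 4-hydroxycyclohexyl at this oxygen, and it amounted to a 1.3-fold lower number from compound 1 to compound 2 (0.11 log units; within the scatter). Among the measured compounds shown here, no measured compound carries an amino group, so the evidence is thin and the range must stay wide. For the measured compounds named here, with only that small step as a guide, no shift beyond the scatter is expected in this assay. The expected change is a 1.0-fold lower number from compound 2 to compound 3 (0.01 log units; within the scatter). Compound 3 is estimated at 3000 nM, within an expected range of 1000 nM to 9000 nM.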

Compound 3, half-maximal inhibitory concentration: > 50000 nM
Compound 3: only a limit was reported; the forecaster's own chance of this, stated with the estimate: 5%; at least 16-fold (1.22 log units) between middle value and limit.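

In this assay, compound 3 is reported only as a limit and not as a number: the limit of > 50000 nM in this assay, at which 1 of the 3 values shown sits.

Compounds 1 and 2 had suggested that this oxygen on an aromatic ring tolerates a change of group, but the position proves far from indifferent: 4-aminophenyl in place of 4-hydroxycyclohexyl brings an at least 16-fold higher number from compound 2 to compound 3 (1.20 log units; beyond the scatter), and 4-aminophenyl in place of 3-hydroxybenzyl brings an at least 12-fold higher number from compound 1 to compound 3 (1.09 log units; beyond the scatter). The loss also appears although the entering and leaving groups match in heavy atoms, hydrogen-bond donors, hydrogen-bond acceptors and net charge, so those counts alone do not track the result in these three compounds.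

The change to compound 3 swaps a non-aromatic ring for an aromatic one and a hydroxyl for an amine in a single step, and these compounds cannot say which of the two matters, or whether both do. A 4-hydroxyphenyl or a 4-aminocyclohexyl group on the same oxygen would separate the two, and a 3-aminobenzyl group would show whether the amine is tolerated when the ring stands one carbon further out.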